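The source may report more compounds than this note shows. Statements on the series, on what has been measured and on what is new or still open speak of the compounds shown alone.

In an in vivo ADME assay on the whole organism for metabolic stability, with Mus musculus as the target, read by LC-MS, at a dose of 320 mg/kg by the oral route (a lower number here means that the compound disappears faster, a higher number that the compound lasts longer), compound 1 `CC(C)/N=C(\NC1=NC(=O)CN1C(C)C)Nc1ccc(Cl)c(Cl)c1` gives 0.283 h. Compound 2 `CCC(CC)C(=O)/N=C(\NC1=NC(=O)CN1c1cccc(Cl)c1Cl)NC(C)C` is known in this assay only as a limit, reported as > 1 h. That value sits at the limit of > 1 h in this assay, at which 1 of the 2 values shown sits, so its true half-life is not pinned down. Compound 3 `CC(C)N/C(=N/C(=O)OC(C)(C)C)NC1=NC(=O)CN1c1cccc(Cl)c1Cl` has not yet been measured in this assay; it differs from compound 2 by tert-butoxy in place of pentan-3-yl on a carbonyl carbon. Among the measured compounds shown here, with no measured step between compounds of this kind, the expected step from compound 2 to compound 3 in this assay is an at least 1.2-fold lower number from compound 2 to compound 3 (0.09 log units; that floor lies within the scatter), a modest shortening that may not exceed the usual scatter. Compound 3 is therefore estimated at 0.8 h, within a range from 0.3 h to 2.5 h.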

Compound 3, half-life: > 1 h
Compound 3 gave a limit, no number; the forecaster's own chance of this, stated with the estimate: 40%; middle value at least 1.2-fold (0.09 log units) from the limit.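

Compound 2 and compound 3 each give only a limit, so no step can be read between them: the limit of > 1 h in this assay, at which 2 of the 3 values shown sit. From the compounds shown here alone, how long either compound truly lasts in this assay, and whether tert-butoxy in place of pentan-3-yl changes that, stays open.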